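The compounds below may be only part of what the source reports. "The series", "measured", "known", "first", "only" and "open" are said of these compounds alone.

Of the compounds shown here, two sharing one core have been measured in a functional assay on SMMC-7721 cells (Homo sapiens) for antiproliferative activity, read by MTT assay, with a stated time of 48 h; on this read-out lower numbers stand for stronger inhibition and higher numbers for weaker inhibition. Among the measured compounds shown here, compound 1 `Cn1cc(C2=C(c3nn(CCCn4cccc4)c4ncccc34)C(=O)N(c3ccccc3)C2=O)c2ccccc21` is the first of them; in this assay compound 1 gives > 100000 nM, which is a limit of the assay rather than a number. Compound 2 `Cn1cc(C2=C(c3nn(CCCN4CCCCC4)c4ncccc34)C(=O)N(c3ccc(Cl)cc3)C2=O)c2ccccc21` is the second; in this assay compound 2 gives > 100000 nM, again a limit and not a number. Compound 2 thus stands at the edge of what the assay reports, and compound 1 stands there too: the limit of > 100000 nM in this assay, at which 2 of the 2 values shown sit. For the measured compounds named here, no step between measured compounds can be drawn from two limits. Compound 3 `Cn1cc(C2=C(c3nn(CCCN4CCCCC4)c4ncccc34)C(=O)NC2=O)c2ccccc21` has not yet been measured in this assay. It differs from compound 2 in one place: hydrogen in place of 4-chlorophenyl on an amide-type nitrogen in a ring. With both recorded values sitting at the limit, the measured compounds give no guide to the size or direction of this change, and any expectation rests on the structural change alone. The step from compound 2 to compound 3 is expected to be an at least 3.3-fold lower number from compound 2 to compound 3 (0.52 log units; beyond the scatter), toward stronger inhibition, though a value at the limit remains quite possible. Compound 3 is estimated at 30000 nM, within a range from 3000 nM to 100000 nM.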

Compound 3, half-maximal inhibitory concentration: 7670 nM
Beside the measured number, compound 3's estimate is 3.9-fold (0.59 log units) above it; the range from low to high includes it.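

Among the compounds shown here, replacing the 4-chlorophenyl with hydrogen on the amide-type nitrogen in a ring gives, in this assay, an at least 13-fold lower number from compound 2 to compound 3 (1.11 log units; beyond the scatter), the first step that can be read at all, and it shows that this position can carry the antiproliferative read-out from the limit to a measurable number. As far as these compounds go, compound 2 gives > 100000 nM, which is a limit of the assay and not a number, so the step is a lower bound and its full size stays unknown. Compound 3 is the only compound shown to give a number, while the others remain at one bound: the limit of > 100000 nM in this assay, at which 2 of the 3 values shown sit.

The compounds shown do not separate the loss of the 4-chlorophenyl from the presence of the amide hydrogen, and a methyl or a benzyl group on the same nitrogen would be needed to tell these two apart. From the compounds shown here alone, it also remains open whether hydrogen at this nitrogen would have a similar effect with the different side chain that compound 1 carries.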